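This account rests on a few compounds, and the source may have more. Where it says the series, first, only, none or still open, it means among the compounds named here.

Compound 1 `O=C(Nc1ccc(Cl)cc1)Nc1cccc(CNc2nccnc2Cl)c1` stands lowest of the two numbers measured in a functional assay on MGC-803 cells (Homo sapiens) for antiproliferative activity, read by MTT assay, with a stated time of 48 h (a higher number here means a weaker inhibitor, a lower number a stronger inhibitor), where compound 1 gives 4980 nM. Compound 2 `Cc1ccccc1NC(=O)Nc1cccc(CNc2nccnc2Cl)c1` gives 14000 nM, and the step of a 2.8-fold higher number from compound 1 to compound 2 (0.45 log units; beyond the scatter) came with 2-methylphenyl in place of 4-chlorophenyl on an amide-type nitrogen. Compound 3 `O=C(Nc1cccc(CNc2nccnc2Cl)c1)Nc1ccccc1Cl` is yet to be measured. Its change from compound 1 is 2-chlorophenyl in place of 4-chlorophenyl on an amide-type nitrogen. Within the data shown here, the one measured step that bears on it is a 2.8-fold higher number from compound 1 to compound 2 (0.45 log units; beyond the scatter), modest yet beyond the scatter, so a rise of similar size is expected here. Compound 3 is estimated at 9000 nM, within 4000 nM to 20000 nM. The expected step is a 1.8-fold higher number from compound 1 to compound 3 (0.26 log units; within the scatter).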

Compound 3, half-maximal inhibitory concentration: 7130 nM
Compound 3: middle estimate off by 1.3-fold (0.10 log units), on the high side; measured number inside the range.
By their numbers in this assay, from the lowest: compounds 1, 3 and 2 (each within the scatter of the next, the first and the last beyond it).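

Putting 2-chlorophenyl in place of 4-chlorophenyl on this amide-type nitrogen gives a 1.4-fold higher number from compound 1 to compound 3 (0.16 log units; within the scatter) in this assay, so these two placements of the chlorine cannot be told apart here. Chloro in place of methyl on an aromatic carbon gives a 2.0-fold lower number from compound 2 to compound 3 (0.29 log units; within the scatter), so this swap cannot be told apart from no change either. Nothing available explains these results.

Still open, from the compounds shown here alone, is how 3-chlorophenyl, 4-methylphenyl or unsubstituted phenyl would compare on this nitrogen. Also open, going by these compounds, is whether a methoxy group on that ring would give a clearly different number.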